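The source may hold more compounds than are shown below. What is called first, only, known or untested is meant among the compounds shown, and "the series" means these compounds.

Measured so far in an ADME assay on Vero cells (Chlorocebus sabaeus) for cytotoxicity; a higher number here means that more compound is tolerated, a lower number that less compound is tolerated:
Compound 1 `O=C(O)c1cccc(-c2ccc(/C=C3\S/C(=N\c4ccccc4)N(c4ccc(Cl)cc4)C3=O)o2)c1` gives a limit of > 200000 nM.
Compound 2 `O=C(O)c1cccc(-c2ccc(/C=C3\S/C(=N\c4ccccc4)N(c4ccc(F)cc4)C3=O)o2)c1` gives a limit of > 200000 nM.
Compound 3 `O=C(O)c1cccc(-c2ccc(/C=C3\S/C(=N\c4ccc(F)cc4)N(c4ccccn4)C3=O)o2)c1` gives a limit of > 200000 nM.

None of these three values is a number; each is a limit of this assay, and the limit of > 200000 nM in this assay, at which 3 of the 3 values shown sit, records that all three sit there. The step that the two limits leave unreadable from compound 2 to compound 1 is made by the change (chloro in place of fluoro on an aromatic carbon), and its size cannot be read because the limit of > 200000 nM in this assay, at which 3 of the 3 values shown sit, covers both of its ends.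

Compound 4 `O=C(O)c1cccc(-c2ccc(/C=C3\S/C(=N\c4ccc(Cl)cc4)N(c4ccccn4)C3=O)o2)c1` has not yet been measured in this assay. Among the measured compounds shown here, it differs from compound 3 by chloro in place of fluoro on an aromatic carbon, the same change, at the same place, as the one that separates compound 2 and compound 1. How the core of compound 3 differs from the core of compound 2 is not broken down here.

For compound 4 the step of a number no higher from compound 3 to compound 4 (the limit leaves the size open) is expected, set beside the earlier unreadable one, and this rests on compound 3 sitting at the limit of > 200000 nM in this assay, at which 3 of the 3 values shown sit. Compound 4 is therefore expected to give about 200000 nM in this assay, between 100000 nM and 400000 nM, most likely again as a limit.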

Compound 4, half-maximal cytotoxic concentration: > 200000 nM
Compound 4: only a limit was reported; the forecaster's own chance of this, stated with the estimate: 85%; the middle value lies on the limit itself.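

In this assay compound 4 gives > 200000 nM, which is a limit and not a number. No step can be read from compound 3 to compound 4, because both ends rest on the same limit: the limit of > 200000 nM in this assay, at which 4 of the 4 values shown sit.

The compounds shown leave open what number any of them would give in this assay, and whether chloro in place of fluoro changes it.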